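Dropping the methoxy group from compound 1

A few compounds are considered here, and "the series" means these few. Any claim that something is new, unique, unknown or untested is made for them only; others in the source may bear on it.

Measured compounds and their values:
compound 1 `COc1ccc(-c2nnc(SC/C(=N/O)c3ccccc3)n2-c2ccccc2)cc1`: 73%
compound 2 `CCn1c(SCC(=O)c2ccccc2)nnc1-c1ccc(OC)cc1`: 61%

Compound 1 holds the highest of the two numbers measured in a functional assay on the whole organism (strain albino) for inhibition, with Rattus norvegicus as the target, read by paw edema, with a stated time of 5 h, at a dose of 0.28 mmol/kg by the oral route (on this read-out higher numbers stand for more inhibition at the one dose given (going by the name of the read-out) and lower numbers for less inhibition), and the nearest number, that of compound 2, lies a margin lower that is beyond the usual scatter. For the measured compounds named here, no single-point step between measured compounds is available, so how much a change at one place moves the read-out in this assay has not been seen. Compound 3 `O/N=C(/CSc1nnc(-c2ccccc2)n1-c1ccccc1)c1ccccc1` differs from compound 1 by hydrogen in place of methoxy on an aromatic carbon; the methoxy leaves and a hydrogen enters. Going by the values given here, with no measured step to lean on, the expected step of a number 8 percentage points lower from compound 1 to compound 3 (within the scatter) is a modest lowering that may well stay within the scatter. Compound 3 is therefore estimated at 65%, with a range from 50% to 78%.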

Compound 3, a percentage reported as inhibition, in the whole organism at one dose (the size of the read-out at that dose, not a potency): 75%
Estimate against measurement, compound 3: 10 percentage points below; the range from low to high includes it.
By their numbers in this assay, from the lowest: compound 2; then compounds 1 and 3 (each within the scatter of the next).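

Replacing methoxy with hydrogen gives a number 2 percentage points higher from compound 1 to compound 3 (within the scatter) in this assay, the first step at a single place among these compounds. On this aromatic carbon, para to a large group, the read-out at the one dose given therefore does not separate 4-methoxyphenyl from phenyl, so in this pair the methoxy group is not required for a value at this level. No measurement shown here offers an explanation for this result.

The compounds shown leave open whether a different group at this place, such as an amine, a carboxylic acid or the longer ethoxy chain, would move the read-out beyond the scatter. They also leave open whether the same exchange would behave alike on the core of compound 2, which differs from compound 1 in more than one place.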